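The source may report more compounds than this note shows. Statements on the series, on what has been measured and on what is new or still open speak of the compounds shown alone.

Working notes on the cytotoxicity side of the series.

Compound 1 `O=C1/C(=C/c2ccn(Cc3ccccc3)c2)S/C(=N\c2ccccc2)N1C1CCCCC1` and compound 3 `CN1C(=O)/C(=C/c2ccn(Cc3ccccc3)c2)S/C1=N\c1ccccc1` share one core and differ in a single place, while compound 2 `O=C1/C(=C/c2cnn(-c3ccccc3C(F)(F)F)c2)S/C(=N\c2ccccc2)N1C1CCCCC1` and the not yet measured compound 4 `CN1C(=O)/C(=C/c2cnn(-c3ccccc3C(F)(F)F)c2)S/C1=N\c1ccccc1` carry a second core; the difference between the two cores is not broken down here. Every value comes from an ADME assay on L6 cells (Rattus norvegicus) for cytotoxicity, read by microscopy and resazurin assay, with a stated time of 72 h; on this read-out lower numbers stand for an effect already at smaller amounts and higher numbers for an effect only at larger amounts of compound. In this assay compound 1 gives > 200000 nM, which is a limit of the assay and not a number. In this assay compound 3 gives > 240000 nM, again a limit. In this assay compound 2 gives > 180000 nM, also a limit.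

The change methyl in place of cyclohexyl on an amide-type nitrogen in a ring produces a step that the two limits leave unreadable from compound 1 to compound 3, unreadable because the limit of > 200000 nM in this assay, at which 1 of the 3 values shown sits, and the limit of > 240000 nM in this assay, at which 1 of the 3 values shown sits, both mark a limit rather than a number. The change from compound 2 to compound 4 is the same change, (methyl in place of cyclohexyl on an amide-type nitrogen in a ring), and the place is identical word for word. Compound 2 itself sits at a limit, as the limit of > 180000 nM in this assay, at which 1 of the 3 values shown sits, states, so nothing measured about this change reaches a number within the range tested.

Compound 4 is therefore expected to show a step that the limit leaves unreadable from compound 2 to compound 4 in this assay, with the most likely outcome being another limit. The estimate for compound 4 in this assay is 250000 nM, with an expected range from 100000 nM to 1000000 nM.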

Compound 4, half-maximal effective concentration: 180000 nM
Compound 4: middle estimate off by 1.4-fold (0.14 log units), on the high side, within the range that was stated.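

In this assay, methyl in place of cyclohexyl on an amide-type nitrogen in a ring gives a number no higher from compound 2 to compound 4 (the limit leaves the size open) on the core shared by these two compounds. The size of this step cannot be read because compound 2 sits at a limit and not at a number: the limit of > 180000 nM in this assay, at which 1 of the 4 values shown sits. Compound 4 gives 180000 nM, a measured number, while the matching step on the core of compound 1 cannot be read either, so the series does not show whether the change carries over from one core to the other, or with what size.

Still open, as far as these compounds go, is how other groups on this amide-type nitrogen, such as an ethyl group, a longer chain like n-butyl, a chain ending in an amine or one ending in a carboxylic acid, would read in this assay on either core. For the compounds shown here, also open is whether any such group would give a number on the core of compound 1, and whether a number on that core would sit close to the one for compound 4.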